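This account rests on a few compounds, and the source may have more. Where it says the series, first, only, none or still open, it means among the compounds named here.

Of the compounds shown here, three have so far been tested in a functional assay on HT-29 cells (Homo sapiens) for cytotoxicity, read by XTT assay, with a stated time of 72 h; a lower number here means a stronger inhibitor, a higher number a weaker inhibitor. Compound 1 `CC(C)=CCC/C=C(\C)Cc1c(OC/C=C(\C)CCC=C(C)C)cc(O)c2c(=O)cc(-c3ccccc3)oc12` gives > 100000 nM, which is a limit of the assay rather than a number. Compound 2 `CCCCCCCC/C=C\CCCCCCCCOc1cc(O)c(C(C)=O)c(OCCCCCCCC/C=C\CCCCCCCC)c1` likewise gives > 100000 nM, again a limit. Compound 3 `C=C1CC[C@H]2C(C)(C)CCC[C@]2(C)[C@H]1CC/C(C)=C/COc1cc(O)c2c(=O)c(OC/C=C(\C)CC[C@H]3C(=C)CC[C@H]4C(C)(C)CCC[C@]34C)c(-c3ccc(O)cc3)oc2c1` also reaches only > 100000 nM, a limit and not a measured number. All three therefore sit at the limit of > 100000 nM in this assay, at which 3 of the 3 values shown sit, and nothing separates them from one another. Compound 3 thus stands nowhere in particular: it has no measured potency of its own, only that ceiling. No two of these compounds differ in a single place, so no step between measured compounds can be read from them.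

Compound 4 `C=C1CC[C@H]2C(C)(C)CCC[C@]2(C)[C@H]1CC/C(C)=C/COc1cc(O)c2c(=O)c(OC/C=C(\C)CC[C@H]3C(=C)CC[C@H]4C(C)(C)CCC[C@]34C)c(-c3ccc(OC)cc3)oc2c1` is the next one to be measured in this assay. It differs from compound 3 in one place: methyl in place of hydrogen on an oxygen on an aromatic ring. Methyl in place of hydrogen on an oxygen on an aromatic ring is a small change, and with compound 3 resting at a limit rather than a number, there is no footing for expecting a move of any direction. The step from compound 3 to compound 4 is therefore expected to be a step that the limit leaves unreadable from compound 3 to compound 4, none beyond the scatter. Compound 4 is expected to come in around 150000 nM, within a range of 50000 nM to 500000 nM, and the assay will most likely once more report only a limit.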

Compound 4, half-maximal inhibitory concentration: > 100000 nM
Compound 4: no number, only a limit (the forecaster's own chance of this, stated with the estimate: 85%); the middle value lies beyond the limit too.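

Compound 3 and compound 4 both rest at a limit of this assay rather than at a number, so no step can be read from the change of hydroxy to methoxy. The same holds for every compound shown: the limit of > 100000 nM in this assay, at which 4 of the 4 values shown sit. How strongly any of these compounds acts, and whether that change alters it, stays open.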